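Thiophene replaces formylphenyl on the shared core

This account rests on a few compounds, and the source may have more. Where it says the series, first, only, none or still open, it means among the compounds named here.

Compound 1 `O=Cc1ccc(-c2cn3ccnc3c(-c3ccc4ncn(C5CCCCC5)c4c3)n2)cc1` stands highest of the two measured numbers in a functional assay on SN12C cells (Homo sapiens) for inhibition, read by sulforhodamine B assay, with a stated time of 48 h, tested at 10 uM (a higher number here means more inhibition at the concentration tested (going by the name of the read-out), a lower number less inhibition), where compound 1 gives 20.7%. Compound 2 `Brc1ccc(-c2cn3ccnc3c(-c3ccc4ncn(C5CCCCC5)c4c3)n2)cc1` gives 18.4% in this assay; the step of a number 2.3 percentage points lower from compound 1 to compound 2 (within the scatter) lies within the scatter, so no order between compound 1 and compound 2 can be read from it. Compound 3 `c1csc(-c2cn3ccnc3c(-c3ccc4ncn(C5CCCCC5)c4c3)n2)c1` has not yet been measured in this assay. It differs from compound 1 as follows: thiophen-2-yl in place of 4-formylphenyl on an aromatic carbon. Among the compounds with values here, the only measured step, a number 2.3 percentage points lower from compound 1 to compound 2 (within the scatter), exchanges a group on an aromatic carbon and stays within the scatter; it does not cover thiophen-2-yl, and no other step bears on this change. The expected step in this assay is therefore a number 2.7 percentage points lower from compound 1 to compound 3 (within the scatter), meaning no change beyond the scatter in either direction. Compound 3 is estimated at 18%, with a range from 5% to 32%.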

Compound 3, a percentage reported as inhibition, at one concentration (the size of the read-out at that concentration, not a potency): 2.84%
Compound 3: the middle estimate sits 15.2 percentage points above what was measured; the measured number lies below the stated range.
By their numbers in this assay, from the lowest: compound 3; then compounds 2 and 1 (each within the scatter of the next).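

In this assay, the position on the aromatic carbon of the shared core does respond to a change of group: thiophen-2-yl gives a number 17.9 percentage points lower from compound 1 to compound 3 (beyond the scatter), and the same holds against the bromo compound, with a number 15.6 percentage points lower from compound 2 to compound 3 (beyond the scatter). Within the data shown here, the exchange between 4-formylphenyl and 4-bromophenyl stayed within the scatter, so this is the first change at this position to move the number beyond it, leaving compound 3 the lowest of the three. No measurement on hand accounts for this difference.

The step to thiophen-2-yl changes the ring and removes the substituent at once, so the compounds shown do not tell which of the two goes with the lower number. An unsubstituted phenyl, or a thiophene carrying a bromo or formyl group, would separate these two changes.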